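Urea terminus: dichlorophenyl to trifluoromethylphenyl exchange

This account rests on a few compounds, and the source may have more. Where it says the series, first, only, none or still open, it means among the compounds named here.

Measured so far:
compound 1 `COc1cc(-c2nn(-c3cccc(NC(=O)Nc4cc(C(F)(F)F)cc(C(F)(F)F)c4)c3)cc2-c2ccncc2)ccc1Cl`: 49300 nM
compound 2 `COc1cc(-c2nn(-c3cccc(NC(=O)c4cccc(C(F)(F)F)c4)c3)cc2-c2ccncc2)ccc1Cl`: > 50000 nM
compound 3 `COc1cc(-c2nn(-c3cccc(NC(=O)Nc4ccc(Cl)c(Cl)c4)c3)cc2-c2ccncc2)ccc1Cl`: > 50000 nM

In a functional assay on CAKI-1 cells (Homo sapiens) for inhibition, read by sulforhodamine B assay, with a stated time of 48 h (a lower number here means that less compound is tolerated, a higher number that more compound is tolerated), compound 1 gives 49300 nM. For compound 2 the value > 50000 nM is a limit of the assay, not a number. For compound 3 the value > 50000 nM is likewise a limit. Compound 3 thus stands at the ceiling of what was tested, the limit of > 50000 nM in this assay, at which 2 of the 3 values shown sit, being where it sits. Among the measured compounds shown here, the one measured step that touches compound 3, a step that the two limits leave unreadable from compound 2 to compound 3, cannot be read since both ends are limits. Compound 4 `COc1cc(-c2nn(-c3cccc(NC(=O)Nc4cccc(C(F)(F)F)c4)c3)cc2-c2ccncc2)ccc1Cl` is not yet measured; it differs from compound 3 by 3-(trifluoromethyl)phenyl in place of 3,4-dichlorophenyl on an amide-type nitrogen. For the measured compounds named here, no measured step isolates this exchange; the nearest measured analogue, compound 1, gives 49300 nM. Compound 4 is therefore expected to show no step beyond the scatter, a number no higher from compound 3 to compound 4 (the limit leaves the size open), with an estimated value of 50000 nM (range 25000 nM to 100000 nM).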

Compound 4, concentration lethal to 50% of the cells: > 50000 nM
Compound 4: no number, only a limit (the forecaster's own chance of this, stated with the estimate: 65%); the middle value sits exactly at the limit.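

In this assay compound 4 gives only a limit, so 3-(trifluoromethyl)phenyl in place of 3,4-dichlorophenyl on the amide-type nitrogen yields no readable value: the limit of > 50000 nM in this assay, at which 3 of the 4 values shown sit. The steps to compound 4 from compound 2 and compound 3 cannot be read, since both ends are limits. Hydrogen in place of trifluoromethyl on an aromatic carbon gives an at least 1.0-fold higher number from compound 1 to compound 4 (0.00 log units; that floor lies within the scatter), so the second trifluoromethyl has no readable effect here.

Where the compounds at the limit truly lie stays open. Also open, from the compounds shown here alone, is whether an amine or a carboxylic acid on the terminal phenyl would give a clearly lower number.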